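Ester position on the piperidine in a trypsin series

A few compounds are considered here, and "the series" means these few. Any claim that something is new, unique, unknown or untested is made for them only; others in the source may bear on it.

Compound 1 `CCOC(=O)C1CCN(c2ccc(N3C[C@H](CNC(=O)c4ccc(Cl)s4)OC3=O)cc2)CC1` carries a 4-(ethoxycarbonyl)piperidin-1-yl group on the shared core. In an assay on isolated protein for inhibition of Trypsin (Homo sapiens), read by spectrophotometry, with a stated time of 15 min (on this read-out lower numbers stand for stronger inhibition and higher numbers for weaker inhibition), compound 1 gives > 100000 nM, which is a limit of the assay and not a number. Compound 2 `CCOC(=O)C1CCCN(c2ccc(N3C[C@H](CNC(=O)c4ccc(Cl)s4)OC3=O)cc2)C1` carries 3-(ethoxycarbonyl)piperidin-1-yl instead. In this assay compound 2 gives > 100000 nM, again a limit rather than a number. The step that the two limits leave unreadable from compound 1 to compound 2 therefore cannot be read, as the limit of > 100000 nM in this assay, at which 2 of the 2 values shown sit, shows: both values sit at the same limit. Compound 3 `CCOC(=O)C1CCCCN1c1ccc(N2C[C@H](CNC(=O)c3ccc(Cl)s3)OC2=O)cc1` has not yet been measured; it differs from compound 1 by 2-(ethoxycarbonyl)piperidin-1-yl in place of 4-(ethoxycarbonyl)piperidin-1-yl on an aromatic carbon. Within the data shown here, the only step that bears on this change, the one from compound 1 to compound 2, gives neither a size nor a direction, so for compound 3 in this assay the expectation is simply another value at or beyond the limit, with no step beyond the scatter. Compound 3 is estimated at 150000 nM, with a range from 50000 nM to 600000 nM. The step that the limit leaves unreadable from compound 1 to compound 3 implied by this estimate is expected to lie within the scatter.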

Compound 3, inhibition constant: > 100000 nM
Compound 3: no number, only a limit; the forecaster's own chance of this, stated with the estimate: 85%; the middle value lies beyond the limit too.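

In this assay, among these compounds, compound 3 gives > 100000 nM, a limit and not a number, so no step among compound 1, compound 2 and compound 3 can be read: the limit of > 100000 nM in this assay, at which 3 of the 3 values shown sit. The compounds shown leave open whether the position of the ethoxycarbonyl group on the piperidine matters at all in this assay, and how far past the limit each compound lies.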